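The compounds below may be only part of what the source reports. "The series", "measured", "known", "first", "only" and "open" are said of these compounds alone.

Compound 1 `Cc1cccc(Nc2nc(-c3ccnc(-c4ccsc4)c3)cs2)c1` — in a functional assay on RCC4 cells (Homo sapiens) for inhibition, read by XTT assay, with a stated time of 4 days (on this read-out higher numbers stand for weaker inhibition and lower numbers for stronger inhibition), compound 1 gives 8700 nM; 8710 nM (2 entries).
Compound 2 `Cc1cccc(Nc2nc(-c3ccnc(CCCO)c3)cs2)c1` — in this assay compound 2 gives 5250 nM.

For the measured compounds named here, compound 2 stands on the single number it has in this assay; a further entry for it gives no single number. Its value and that of compound 1 lie close together, within the usual scatter of such measurements, so neither can be called stronger or weaker than the other. The repeated entries of compound 1 the several entries of compound 1 in this assay, 8700 nM; 8710 nM (2 entries) show how closely readings of one compound can agree.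

Compound 3 `C#Cc1cc(-c2csc(Nc3cccc(C)c3)n2)ccn1` has not yet been measured. It differs from compound 2 by ethynyl in place of 3-hydroxypropyl on an aromatic carbon. Going by the values given here, no measured pair shows what this swap does here, so no step beyond the usual scatter is expected in either direction. Compound 3 is expected at about 6000 nM, between 2000 nM and 18000 nM. That estimate means an expected step of a 1.1-fold higher number from compound 2 to compound 3 (0.06 log units; within the scatter).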

Compound 3, half-maximal inhibitory concentration: 18200 nM
For compound 3 the middle estimate is 3.0-fold (0.48 log units) below the measured one; the whole stated range lies below it.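

On the aromatic carbon next to the ring nitrogen, ethynyl in place of 3-hydroxypropyl gives a 3.5-fold higher number from compound 2 to compound 3 (0.54 log units; beyond the scatter) in this assay, and here a higher number means weaker inhibition. For the compounds shown here, compound 1 and compound 2 carry different groups at this same position yet could not be told apart, so this is the first sign that the group placed here can change the reading. The step is also easy to trust as a real difference, since repeated readings of one compound in this test can agree very closely: the several entries of compound 1 in this assay, 8700 nM; 8710 nM (2 entries)

The swap shortens the group and removes its hydroxyl in a single move, so the compounds shown cannot say which of the two matters. A plain propyl chain would separate those two changes, while an amine or a carboxylic acid at the end of the chain remains an open question.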